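One aromatic group swapped on a shared core

The compounds below may be only part of what the source reports. "The series", "measured", "known", "first", "only" and "open" are said of these compounds alone.

In an ADME assay on NIH3T3 cells (Mus musculus) for cytotoxicity, read by MTT assay, with a stated time of 48 h (a higher number here means a weaker inhibitor, a lower number a stronger inhibitor), compound 2 (`CC(=O)OC1=C(c2cc(C)nc3ccccc23)Oc2cc3ccccc3cc2-n2cccc21`) gives 126 nM and holds the middle of three numbers. The lowest is compound 1 (`CC(=O)OC1=C(c2cccc3cccnc23)Oc2cc3ccccc3cc2-n2cccc21`) with 34 nM in this set, the highest compound 3 (`CCc1cc(C2=C(OC(C)=O)c3cccn3-c3cc4ccccc4cc3O2)c2ccccc2n1`) with 540 nM in this set. Compound 4 (`CC(=O)OC1=C(c2cccc3cnccc23)Oc2cc3ccccc3cc2-n2cccc21`), still unmeasured, carries isoquinolin-5-yl in place of 2-methylquinolin-4-yl on a double-bonded ring carbon, next to the ring oxygen. Among the compounds with values here, two measured steps bear on this. Replacing the group at this place gave a 3.7-fold higher number from compound 1 to compound 2 (0.57 log units; beyond the scatter) and adding a methyl on the chain gave a 4.3-fold higher number from compound 2 to compound 3 (0.63 log units; beyond the scatter) as well. Both are modest rises that come with added carbon in these three compounds, and the new group has no methyl, so a modest fall is expected in this assay here. The expected step is a 2.3-fold lower number from compound 2 to compound 4 (0.36 log units; beyond the scatter) in size. Compound 4 is estimated at 55 nM within a range of 15 nM to 200 nM overall.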

Compound 4, half-maximal inhibitory concentration: 375 nM
Beside the measured number, compound 4's estimate is 6.8-fold (0.83 log units) below it; the whole stated range lies below it.
By their numbers in this assay, from the lowest: compound 1; then compound 2; then compounds 4 and 3 (each within the scatter of the next).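

In this assay, isoquinolin-5-yl in place of 2-methylquinolin-4-yl gives a 3.0-fold higher number from compound 2 to compound 4 (0.47 log units; beyond the scatter), so compound 4 goes against the earlier link between added carbon and a higher number: the entering group has no methyl and fewer heavy atoms. Isoquinolin-5-yl in place of quinolin-8-yl, neither carrying a methyl, gives an 11-fold higher number from compound 1 to compound 4 (1.04 log units; beyond the scatter), so the choice of two-ring aromatic group at this place matters even without a methyl. Nothing available explains these differences. Still open, as far as these compounds go, is how a single phenyl ring, or a quinolin-8-yl group carrying an amine or a carboxylic acid, would behave here.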